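A few compounds are considered here, and "the series" means these few. Any claim that something is new, unique, unknown or untested is made for them only; others in the source may bear on it.

Measured so far:
Compound 1 `CCCOc1c(-c2cc(OC)c(OC)c(OC)c2)oc2ccccc2c1=O`: 5700 nM
Compound 2 `CCN(CC)CCCCOc1c(-c2cc(OC)c(OC)c(OC)c2)oc2ccccc2c1=O`: 13500 nM
Compound 3 `CCCCN(CCCC)CCCCOc1c(-c2cc(OC)c(OC)c(OC)c2)oc2ccccc2c1=O`: 7800 nM

All three values come from a functional assay on LNCaP cells (Homo sapiens) for antiproliferative activity, read by WST assay, with a stated time of 3 days; a lower number here means a stronger inhibitor, a higher number a weaker inhibitor. Compound 3 stands within the scatter of both other compounds, so it cannot be ranked against either of them. The next compound, compound 4 `CCCCN(CCCC)CCCCCOc1c(-c2cc(OC)c(OC)c(OC)c2)oc2ccccc2c1=O`, has no value yet. It differs from compound 3 by (dibutylamino)methyl in place of dibutylamino on a saturated chain carbon, four bonds along the chain from an oxygen on an aromatic ring, which extends 2-(dibutylamino)ethyl to 3-(dibutylamino)propyl.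

Within the data shown here, no measured step makes this exact change, so the nearest evidence is indirect. Placing (diethylamino)methyl on the chain gave a 2.4-fold higher number from compound 1 to compound 2 (0.37 log units; beyond the scatter), while placing (dibutylamino)methyl there gave a 1.4-fold higher number from compound 1 to compound 3 (0.14 log units; within the scatter). Exchanging the amine gave a 1.7-fold lower number from compound 2 to compound 3 (0.24 log units; within the scatter). These steps are small, and only the first exceeds the scatter, so this assay has so far shown little response to changes in this side chain. On that basis, the expected result is a 1.0-fold lower number from compound 3 to compound 4 (0.02 log units; within the scatter), with no clear shift in either direction. For compound 4 the estimated value is 7500 nM, with an expected range of 3500 nM to 15000 nM.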

Compound 4, half-maximal inhibitory concentration: 7800 nM
Estimate against measurement, compound 4: 1.0-fold (0.02 log units) below; the measured number falls inside the stated range.
By their numbers in this assay, from the lowest: compounds 1, 3, 4 and 2 (each within the scatter of the next, the first and the last beyond it).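

In this assay, among these compounds, the step from 2-(dibutylamino)ethyl to 3-(dibutylamino)propyl gave no change at the digits printed from compound 3 to compound 4 (within the scatter) and so gives the first direct reading of chain extension with the amine held as dibutylamino. Compound 4 also cannot be separated from the other two compounds, with a 1.7-fold lower number from compound 2 to compound 4 (0.24 log units; within the scatter) and a 1.4-fold higher number from compound 1 to compound 4 (0.14 log units; within the scatter) both printed for it, so at this position neither this extension nor the 2-(dibutylamino)ethyl group on the chain of compound 1 gives a readable shift. No measured evidence accounts for this flat response.

As far as these compounds go, whether a longer chain would stay equally flat in this assay remains open. So does whether a ring amine such as piperidine or morpholine, or a carboxylic acid at the chain end, would move the number beyond the scatter.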